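Replacing Phenyl with 4-Methylcyclohexyl on Compound 1

The source may report more compounds than this note shows. Statements on the series, on what has been measured and on what is new or still open speak of the compounds shown alone.

Among the compounds with values here, in a functional assay on HCT-116 cells (Homo sapiens) for cytotoxicity, read by sulforhodamine B assay, with a stated time of 48 h (on this read-out lower numbers stand for stronger inhibition and higher numbers for weaker inhibition), compound 1 (`CC(=O)n1nc(NC(=O)c2ccccc2)c2c1CN(C(=O)c1ccccc1)C2`) gives 580 nM as the lower of the two numbers measured so far. The nearest neighbour is compound 2 (`O=C(Nc1nn(C(=O)C2CC2)c2c1CN(C(=O)c1ccccc1)C2)c1ccccc1`), and on the same scale compound 2 gives 1240 nM. Within the data shown here, the one measured step is a 2.1-fold higher number from compound 1 to compound 2 (0.33 log units; beyond the scatter) and it is modest, with cyclopropyl in place of methyl on a carbonyl carbon.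

Compound 3 (`CC(=O)n1nc(NC(=O)c2ccccc2)c2c1CN(C(=O)C1CCC(C)CC1)C2`) keeps the core of compound 1 and alters a different carbonyl group. The change 4-methylcyclohexyl in place of phenyl on a carbonyl carbon puts 4-methylcyclohexyl in place of phenyl on a carbonyl carbon bound to an amide-type nitrogen in a ring. Among the measured compounds shown here, no measured step covers this place, so compound 2 offers only a loose guide, and its modest rise is the sole evidence available. A rise of similar size in this assay is therefore expected, though its direction remains uncertain. The estimated change is a 1.9-fold higher number from compound 1 to compound 3 (0.28 log units; within the scatter) and it carries a wide margin. Compound 3 is expected at 1100 nM within an estimated range from 350 nM to 3500 nM at its upper end.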

Compound 3, half-maximal inhibitory concentration: 12200 nM
Estimate against measurement, compound 3: 11-fold (1.04 log units) below, outside the stated range (above it).
By their numbers in this assay, from the lowest: compound 1; then compound 2; then compound 3.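

In this assay, within the data shown here, putting 4-methylcyclohexyl in place of phenyl on a carbonyl carbon bound to an amide-type nitrogen in a ring gives a 21-fold higher number from compound 1 to compound 3 (1.32 log units; beyond the scatter), a large step and the first measured change at this place. It shows that the read-out is far from indifferent to this group, and this step is much larger than the modest 2.1-fold higher number from compound 1 to compound 2 (0.33 log units; beyond the scatter), which belongs to cyclopropyl in place of methyl on the other carbonyl group. No measurement bearing on the size of this step is available, so the result records the change in cytotoxicity without accounting for it.

The change replaces an aromatic ring with a non-aromatic one and also adds a carbon, so the compounds shown leave open which of these two differences matters; plain cyclohexyl or 4-methylphenyl on this carbonyl carbon would separate them. They also leave open whether any group other than phenyl is tolerated here, for example a smaller acetyl group or a phenyl ring carrying an amine.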